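The compounds below may be only part of what the source reports. "The series", "measured", "known", "first", "only" and "open" are said of these compounds alone.

Notes on the step to compound 4, read in a functional assay on HepG2 cells (Homo sapiens) for inhibition, read by MTT assay, with a stated time of 72 h; on this read-out higher numbers stand for weaker inhibition and lower numbers for stronger inhibition. Within the data shown here, compound 3 `COc1cc(O)cc(O)c1C(=O)/C=C/c1ccc(C)cc1` gives > 50000 nM, which is a limit and not a number, and this is the only such reading in the set: the limit of > 50000 nM in this assay, at which 1 of the 3 values shown sits. Compound 2 `COc1ccc(/C=C/C(=O)c2c(O)cc(O)cc2OC)cc1` gives 18100 nM. Methyl in place of methoxy on an aromatic carbon gave an at least 2.7-fold higher number from compound 2 to compound 3 (0.44 log units; beyond the scatter). Compound 4 `COc1cc(O)cc(O)c1C(=O)/C=C/c1ccc(Cl)cc1` has chloro in place of methyl on an aromatic carbon, para to a large group: chloro in place of methyl on an aromatic carbon. Compound 1 `COc1cc(O)c(CC=C(C)C)c(O)c1C(=O)/C=C/c1ccc(Cl)cc1` holds the same 4-chlorophenyl group, differs elsewhere, and gives 10100 nM. Both readings suggest that the methyl is not favoured, so a modest move towards stronger inhibition is expected in this assay. The expected change is an at least 1.9-fold lower number from compound 3 to compound 4 (0.28 log units; that floor lies within the scatter). For compound 4 the estimate is 26000 nM, with an expected range of 11000 nM to 50000 nM.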

Compound 4, half-maximal inhibitory concentration: 12200 nM
Compound 4: the middle estimate sits 2.1-fold (0.33 log units) above what was measured, within the range that was stated.
By their numbers in this assay, from the lowest: compounds 1, 4 and 2 (each within the scatter of the next). At a limit, above all of these: compound 3.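

At the aromatic carbon para to a large group, 4-chlorophenyl in place of 4-methylphenyl gives an at least 4.0-fold lower number from compound 3 to compound 4 (0.61 log units; beyond the scatter) in this assay, so the methyl reading is not shared by every other group there. Chloro and methoxy on this carbon do not separate, with a 1.5-fold lower number from compound 2 to compound 4 (0.17 log units; within the scatter), and neither do hydrogen and 3-methylbut-2-en-1-yl on the core, with a 1.2-fold higher number from compound 1 to compound 4 (0.08 log units; within the scatter). Compound 3 gives a limit and not a number: the limit of > 50000 nM in this assay, at which 1 of the 4 values shown sits.

As far as these compounds go, how an amine or a carboxylic acid on this carbon would read remains open. So does whether 3-methylbut-2-en-1-yl stays without effect alongside methoxy.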